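Propanoyl to propylcarbonyl: one chain step in the series

This account rests on a few compounds, and the source may have more. Where it says the series, first, only, none or still open, it means among the compounds named here.

In a functional assay on HepG2 cells (Homo sapiens) for antiproliferative activity, read by MTT assay, with a stated time of 72 h (a lower number here means a stronger inhibitor, a higher number a weaker inhibitor), compound 3 (`CCC(=O)NNC(=O)c1csc2ncc(-c3ccc(Br)cc3)n12`) gives 19200 nM. Compound 1 (`CCCC(=O)NNC(=O)c1csc2ncc(-c3ccc(C)cc3)n12`) gives 26800 nM, and compound 2 (`CCCC(=O)NNC(=O)c1csc2ncc(-c3ccc(OC)cc3)n12`) gives 38000 nM. Compound 3 therefore stands within the scatter of both.

Compound 4 (`CCCC(=O)NNC(=O)c1csc2ncc(-c3ccc(Br)cc3)n12`) differs from compound 3 by methyl in place of hydrogen on a saturated chain carbon, two bonds along the chain from a carbonyl carbon. This turns propanoyl into propylcarbonyl.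

For the measured compounds named here, no measured step covers this change. Going by the values given here, the only measured step, a 1.4-fold higher number from compound 1 to compound 2 (0.15 log units; within the scatter), is methoxy in place of methyl on an aromatic carbon, so it bears only indirectly on the series as a whole. Compound 1 and compound 2 already carry the propylcarbonyl chain, and their values show no separation from compound 3 beyond the scatter, although their aromatic substituents differ from that of compound 3.

No change beyond the scatter is therefore expected, and the estimated step is a 1.1-fold higher number from compound 3 to compound 4 (0.04 log units; within the scatter). For compound 4 the expected value is 21000 nM, with an estimated range from 11000 nM to 40000 nM.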

Compound 4, half-maximal inhibitory concentration: 33600 nM
The estimate for compound 4 lay 1.6-fold (0.20 log units) below the measured number, and the stated range covers the measured number.
By their numbers in this assay, from the lowest: compounds 3, 1, 4 and 2 (each within the scatter of the next).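

In this assay, methyl in place of hydrogen on a saturated chain carbon, two bonds along the chain from a carbonyl carbon, now has a direct reading: a 1.8-fold higher number from compound 3 to compound 4 (0.24 log units; within the scatter). The change from propanoyl to propylcarbonyl therefore stays inside the scatter for this bromo compound. With the propylcarbonyl chain held fixed, bromo can also be read on the aromatic carbon, as a 1.1-fold lower number from compound 2 to compound 4 (0.05 log units; within the scatter) and a 1.3-fold higher number from compound 1 to compound 4 (0.10 log units; within the scatter), so bromo, methoxy and methyl all lie within the scatter of one another, and no measurement at hand offers an explanation for any of these steps.

Going by these compounds, whether a longer chain such as pentanoyl, or a chain ending in an amine or a carboxylic acid, would leave the scatter remains open. Propanoyl appears here only with bromo, so its pairing with methyl or methoxy also remains open.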